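Methoxy in Place of Chloro: Expectation for Compound 4

This account rests on a few compounds, and the source may have more. Where it says the series, first, only, none or still open, it means among the compounds named here.

Of the compounds shown here, three have been measured so far in a functional assay on the whole organism (strain Wistar) for inhibition, with Rattus norvegicus as the target, read by paw edema, with a stated time of 1 h, at a dose of 10 mg/kg by the intraperitoneal route; on this read-out higher numbers stand for more inhibition at the one dose given (going by the name of the read-out) and lower numbers for less inhibition. Compound 1, `COc1cccc(/C=N/NC(=O)c2cccnc2Nc2cccc(C(F)(F)F)c2)c1`, gives 58.8%. Compound 2, `CNc1ncccc1C(=O)N/N=C/c1ccccc1`, gives 67.6%. Compound 3, `CNc1ncccc1C(=O)N/N=C/c1cccc(Cl)c1`, gives 68.6%, the highest of the three numbers, though its nearest neighbour compound 2 and even compound 1 lie within the usual scatter of it, so no ordering among them can be claimed.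

Compound 4, `CNc1ncccc1C(=O)N/N=C/c1cccc(OC)c1`, has not yet been measured. It differs from compound 3 in one place: methoxy in place of chloro on an aromatic carbon. Within the data shown here, the only measured step that bears on this position is the one from compound 2 to compound 3, where chloro replaced hydrogen and gave a number 1 percentage points higher from compound 2 to compound 3 (within the scatter). That step was within the scatter, so the number stayed level across that change. Compound 1 carries a methoxy at the same kind of position on a different core and gives a similar number.

Compound 4 is therefore expected to give 66% (range 55% to 77%), a step of a number 2.6 percentage points lower from compound 3 to compound 4 (within the scatter), expected to fall within the scatter.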

Compound 4, a percentage reported as inhibition, in the whole organism at one dose (the size of the read-out at that dose, not a potency): 64.6%
For compound 4 the middle estimate is 1.4 percentage points above the measured one; the measured number falls inside the stated range.
By their numbers in this assay, from the lowest: compounds 1, 4, 2 and 3 (each within the scatter of the next).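

In this assay, methoxy on this aromatic carbon gives no readable change from chloro (a number 4 percentage points lower from compound 3 to compound 4 (within the scatter)) or from hydrogen (a number 3 percentage points lower from compound 2 to compound 4 (within the scatter)), so all three groups now sit level at this place, where earlier only chloro and hydrogen could be compared on the shared core. Among these compounds, the new compound also gives the first reading of the nitrogen on the aromatic ring, where methyl in place of 3-(trifluoromethyl)phenyl, with methoxy held constant, stays within the scatter (a number 5.8 percentage points higher from compound 1 to compound 4 (within the scatter)). No measurement here offers an explanation for these level results.

Whether any group at this aromatic carbon can move the number beyond the scatter remains open, since a carboxylic acid or an amine there is not among the compounds shown. On these data alone, it is equally open whether a chain longer than methyl on the nitrogen would do so.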